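This account rests on a few compounds, and the source may have more. Where it says the series, first, only, none or still open, it means among the compounds named here.

Compound 3 `O=C(CSc1nc(Nc2ccccc2)c2ccccc2n1)Nc1ccc(Cl)cc1` gives 8040 nM in a functional assay on NCI-H1975 cells (Homo sapiens) for inhibition, read by MTT assay, with a stated time of 72 h; on this read-out higher numbers stand for weaker inhibition and lower numbers for stronger inhibition. Of the three measured compounds its number is the second highest: compound 1 `O=C(CSc1nc(Nc2ccccc2)c2ccccc2n1)Nc1cccc(F)c1` gives 6790 nM, and the step of a 1.2-fold higher number from compound 1 to compound 3 (0.07 log units; within the scatter) lies within the scatter, while compound 2 `O=C(CSc1nc(Nc2ccccc2)c2ccccc2n1)Nc1ccc(F)cc1` gives 16500 nM, and the step of a 2.1-fold lower number from compound 2 to compound 3 (0.31 log units; beyond the scatter) lies beyond it. Compound 4 `O=C(CSc1nc(Nc2ccccc2)c2ccccc2n1)Nc1ccc(Cl)c(Cl)c1` differs from compound 3 by chloro in place of hydrogen on an aromatic carbon, so the 4-chlorophenyl becomes a 3,4-dichlorophenyl. Among the compounds with values here, two measured steps bear on this. The step of a 2.1-fold lower number from compound 2 to compound 3 (0.31 log units; beyond the scatter) shows that chloro in place of fluoro on the aromatic carbon moved the number modestly downward, and the step of a 2.4-fold higher number from compound 1 to compound 2 (0.39 log units; beyond the scatter) shows that 3-fluorophenyl rather than 4-fluorophenyl went with a modestly lower number. Within the data shown here, both steps are small, and no measured pair shows a second substituent entering the same ring. A modest step downward, or none beyond the scatter, is therefore expected: a 1.6-fold lower number from compound 3 to compound 4 (0.21 log units; within the scatter). Compound 4 is estimated at 5000 nM, with a range from 2000 nM to 14000 nM.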

Compound 4, half-maximal inhibitory concentration: 10400 nM
Beside the measured number, compound 4's estimate is 2.1-fold (0.32 log units) below it; low and high end bracket the measured number.
By their numbers in this assay, from the lowest: compounds 1, 3, 4 and 2 (each within the scatter of the next, the first and the last beyond it).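

Within the data shown here, with a second halogen on the ring for the first time, the chloro placed ortho to the existing chloro group and meta to a large group leaves the read-out in this assay essentially unmoved: a 1.3-fold higher number from compound 3 to compound 4 (0.11 log units; within the scatter). The 3,4-dichlorophenyl also stays within the scatter of both monofluorinated compounds, with a 1.6-fold lower number from compound 2 to compound 4 (0.20 log units; within the scatter) and a 1.5-fold higher number from compound 1 to compound 4 (0.19 log units; within the scatter), so in this small set the added chloro gives no separation from any of the three earlier compounds. No evidence is available to explain this flat result.

The compounds shown leave open whether an amine, a methoxy group or a carboxylic acid at this position would shift the number beyond the scatter. They also leave open how a 3-chlorophenyl, carrying chloro at this position alone, would compare.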